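Fluoro to chloro: expectation for compound 3

The source may hold more compounds than are shown below. What is called first, only, known or untested is meant among the compounds shown, and "the series" means these compounds.

Measured so far in an assay on isolated protein for inhibition of tyrosine-protein kinase receptor UFO (Homo sapiens), read by LC-MS; on this read-out lower numbers stand for stronger inhibition and higher numbers for weaker inhibition:
compound 1, `Cc1nn(C)c(C)c1-c1ccc(-c2nnc(N(C)Cc3ccc4nccn4c3)o2)cc1`, gives 1260 nM
compound 2, `Cc1nn(C)c(C)c1-c1ccc(-c2nnc(N(C)Cc3ccc4nccn4c3)o2)c(F)c1`, gives 1260 nM

Compound 2 stands level with compound 1 on the numbers shown; the one step between them, no change at the digits printed from compound 1 to compound 2 (within the scatter), is flat within the scatter. The next compound, compound 3, `Cc1nn(C)c(C)c1-c1ccc(-c2nnc(N(C)Cc3ccc4nccn4c3)o2)c(Cl)c1`, differs from compound 2 in one place: chloro in place of fluoro on an aromatic carbon. Among the compounds with values here, only one measured step bears on this change, no change at the digits printed from compound 1 to compound 2 (within the scatter), which introduced the very fluoro that compound 3 now exchanges for chloro, and that step moved nothing beyond the scatter. Within the data shown here, no measured pair separates one halogen from another at this place, so there is no direct precedent for the size of a fluoro-to-chloro exchange here. The flat outcome from compound 1 to compound 2 is the only anchor. For compound 3 the expected step is a 1.0-fold higher number from compound 2 to compound 3 (0.01 log units; within the scatter), with no change beyond the scatter anticipated in either direction. Compound 3 is therefore expected to give 1300 nM in this assay, with a range from 500 nM to 3500 nM.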

Compound 3, half-maximal inhibitory concentration: 79.4 nM
Compound 3: middle estimate off by 16-fold (1.21 log units), on the high side; measured number outside the range, below it.
By their numbers in this assay, from the lowest: compound 3; then compounds 1 and 2 (each within the scatter of the next).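

In this assay, the position on the six-membered aromatic ring of carbon only, ortho to a large group and meta to the 1,3,5-trimethyl-1H-pyrazol-4-yl group, proves responsive to the substituent it carries: chloro in place of fluoro gives a 16-fold lower number from compound 2 to compound 3 (1.20 log units; beyond the scatter), and chloro in place of hydrogen gives a 16-fold lower number from compound 1 to compound 3 (1.20 log units; beyond the scatter). Read beside no change at the digits printed from compound 1 to compound 2 (within the scatter), these steps show that the flat result with fluoro did not mean that the position tolerates any change without effect, since hydrogen and fluoro stand level while chloro separates from both. The data on hand offer no measured basis for explaining why chloro separates from fluoro and hydrogen here.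

The compounds shown leave open whether this step is peculiar to chloro or extends to other groups at the same place, such as bromo, methyl, trifluoromethyl or methoxy. They also leave open whether chloro would give a similar step on another carbon of this ring, as all three compounds vary at this one place only.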